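A few compounds are considered here, and "the series" means these few. Any claim that something is new, unique, unknown or untested is made for them only; others in the source may bear on it.

Measured so far:
Compound 1 `N#Cc1ccc(C(=O)NC(=S)N2CCc3c(OCCCCCOc4ccc(Cl)cc4)cccc32)cc1`. In an ADME assay on Huh-7 cells (Homo sapiens) for cytotoxicity (a lower number here means that less compound is tolerated, a higher number that more compound is tolerated), compound 1 reaches only the limit of the assay, > 50000 nM.
Compound 2 `O=C(NC(=S)N1CCc2c(OCCCCCOc3ccc(Cl)cc3)cccc21)c1ccc(Br)cc1`. In this assay compound 2 gives 29100 nM.
Compound 3 `O=C(NC(=S)N1CCc2c(OCCCCCOc3ccc(Cl)cc3)cccc21)c1cccnc1`. In this assay compound 3 gives 11100 nM.

Compound 3 holds the lowest of the two numbers shown; its nearest neighbour is compound 2, with a 2.6-fold lower number from compound 2 to compound 3 (0.42 log units; beyond the scatter). The value of compound 1 is a limit, not a number (the limit of > 50000 nM in this assay, at which 1 of the 3 values shown sits).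

Compound 4 `S=C(NC(=S)N1CCc2c(OCCCCCOc3ccc(Cl)cc3)cccc21)Oc1ccccc1` differs from compound 3 by a group of 9 heavy atoms (7 carbon, 1 oxygen, 1 sulfur; one six-membered aromatic ring of carbon only) in place of a group of 8 heavy atoms (6 carbon, 1 nitrogen, 1 oxygen; one six-membered aromatic ring with 1 hetero atom), on an amide-type nitrogen. Both measured steps ending at compound 3 alter only the aryl group on the carbonyl carbon: an at least 4.5-fold lower number from compound 1 to compound 3 (0.65 log units; beyond the scatter) and a 2.6-fold lower number from compound 2 to compound 3 (0.42 log units; beyond the scatter). Among the compounds with values here, neither replaces the whole (pyridin-3-yl)carbonyl with a group of a different kind, so no measured step matches the change from compound 3 to compound 4 directly. Those aryl swaps shifted the number by modest amounts, so a shift of similar size is expected here, with the direction uncertain and a return toward the numbers of compound 2 judged somewhat more likely, as a 1.4-fold higher number from compound 3 to compound 4 (0.16 log units; within the scatter). Compound 4 is therefore estimated to give 16000 nM in this assay, between 5000 nM and 50000 nM.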

Compound 4, half-maximal cytotoxic concentration: > 50000 nM
Compound 4: no number, only a limit (the forecaster's own chance of this, stated with the estimate: 20%); at least 3.1-fold (0.49 log units) between middle value and limit.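

Replacing the (pyridin-3-yl)carbonyl on the amide-type nitrogen with a group that holds sulfur and a six-membered aromatic ring of carbon only moves the read-out in this assay upward, with an at least 4.5-fold higher number from compound 3 to compound 4 (0.65 log units; beyond the scatter), so the low number of compound 3 does not carry over to this different kind of group. Set against the bromine-bearing group, the change gives an at least 1.7-fold higher number from compound 2 to compound 4 (0.23 log units; that floor lies within the scatter), so this comparison does not separate the two groups beyond the scatter. Compound 4 gives only a limit, so its step from compound 1, which also gives a limit, cannot be read: the limit of > 50000 nM in this assay, at which 2 of the 4 values shown sit.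

Going by these compounds, how far the number of compound 4 lies past that limit stays open. Also open, on these data alone, is whether the sulfur or the oxygen of the entering group carries the change, and what a pyridin-3-yl ring or a morpholine on that group would do.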